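The source may report more compounds than this note shows. Statements on the series, on what has been measured and on what is new or still open speak of the compounds shown alone.

Measured so far in an assay on isolated protein for inhibition of Calpain-1 catalytic subunit (Sus scrofa); a higher number here means a weaker inhibitor, a lower number a stronger inhibitor:
compound 1 `O=C(O)/C(S)=C/c1cccc(F)c1` — 31500 nM
compound 2 `O=C(O)/C(S)=C/c1c[nH]c2cc(I)ccc12` — 300 nM
compound 3 `O=C(O)/C(S)=C/c1c[nH]c2ccc(Br)cc12` — 20 nM

Compound 1 holds the highest number of the three. Compound 2 lies far below it, beyond the scatter, and compound 3 lower still, so compound 1 is the weakest inhibitor of the set. Among the measured compounds shown here, its core is not the core of compound 2 or compound 3, and no single-change step joins compound 1 to either of them; their values show only how low this series can go, not what a halogen swap on the core of compound 1 is worth.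

Compound 4 `O=C(O)/C(S)=C/c1cccc(Br)c1` is the next point. The change from compound 1 is bromo in place of fluoro on an aromatic carbon of the six-membered aromatic ring of carbon only, meta to a group of 6 heavy atoms. For the measured compounds named here, no measured pair shows such a swap on this core, and nothing in the set points to a large move. The expected step is a 1.6-fold lower number from compound 1 to compound 4 (0.20 log units; within the scatter), a small shift toward a lower number that may well sit within the scatter. Compound 4 is therefore estimated at 20000 nM, with a range from 6000 nM to 60000 nM.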

Compound 4, half-maximal inhibitory concentration: 8400 nM
Compound 4: the middle estimate sits 2.4-fold (0.38 log units) above what was measured, and the stated range covers the measured number.
By their numbers in this assay, from the lowest: compound 3; then compound 2; then compound 4; then compound 1.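

In this assay, among the compounds shown here, the first single-change pair of the series puts a size on bromo in place of fluoro on an aromatic carbon, with a 3.8-fold lower number from compound 1 to compound 4 (0.57 log units; beyond the scatter) as a modest step that lies beyond the scatter. This place on the core of compound 1, meta to a group of 6 heavy atoms, therefore responds to the identity of the halogen, a point that compound 2 and compound 3 could not show, as neither is joined to compound 1 by a single change. Nothing at hand bears on the reason for this step.

Going by these compounds, with only fluoro and bromo compared at this place, a single pair sets no trend, and it remains open whether chloro or iodo would fall in line with them, or whether a group of another kind, such as a methoxy group, an amine or a nitrile, would be tolerated here. Also open, on these data alone, is whether bromo in place of fluoro would give a step of similar size on the core of compound 2 and compound 3, or whether this step belongs to the core of compound 1 alone.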